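The source may report more compounds than this note shows. Statements on the series, on what has been measured and on what is new or still open speak of the compounds shown alone.

Measured so far:
compound 1, `O=S(=O)(NCCCNc1nccc(-c2c(-c3cccc(O)c3)nc3sccn23)n1)c1cccc(F)c1`, 93.8%
compound 2, `COc1ccc(S(=O)(=O)NCCNc2nccc(-c3c(-c4ccccc4)nc4sccn34)n2)cc1`, 81.3%
compound 3, `COc1cccc(-c2nc3sccn3c2-c2ccnc(NCCNS(=O)(=O)c3ccc(C(F)(F)F)cc3)n2)c1`, 93.2%

All three were tested in a functional assay on cells (Panel leukemia (Carcinoma cell lines), Homo sapiens) for inhibition, read by sulforhodamine B assay, with a stated time of 48 h, tested at 10 uM; a higher number here means more inhibition at the concentration tested (going by the name of the read-out), a lower number less inhibition. Compound 1 stands highest of the three numbers, but compound 3 lies close enough that the two are within the scatter of repeated measurements, so no order can be read between them. Compound 2 sits lower, and that gap does go beyond the scatter.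

The next compound is compound 4, `COc1cccc(-c2nc3sccn3c2-c2ccnc(NCCCNS(=O)(=O)c3cccc(F)c3)n2)c1`. It differs from compound 1 in one place: methyl in place of hydrogen on an oxygen on an aromatic ring. Going by the values given here, no directly comparable pair of measured compounds shows what this change does by itself. Some guidance comes from compound 3, which carries the 3-methoxyphenyl group and gives a number within the scatter of compound 1, though compound 3 also differs in other parts of the molecule. Compound 4 is therefore expected to give 92%, between 82% and 98%, because compound 3 gives 93.2% while also carrying a 3-methoxyphenyl group. The expected step is a number 1.8 percentage points lower from compound 1 to compound 4 (within the scatter), which means no change beyond the scatter.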

Compound 4, a percentage reported as inhibition, at one concentration (the size of the read-out at that concentration, not a potency): 93.8%
Compound 4: the middle estimate sits 1.8 percentage points below what was measured, within the range that was stated.
By their numbers in this assay, from the lowest: compound 2; then compounds 3, 1 and 4 (each within the scatter of the next).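

Going by these compounds alone, this is the first pair of compounds here that differ in only one place, so the change from hydroxy to methoxy can now be read by itself. In this assay, methyl in place of hydrogen on the oxygen gives no change at the digits printed from compound 1 to compound 4 (within the scatter), so at this position, the 3-hydroxyphenyl and 3-methoxyphenyl groups cannot be told apart at the single concentration tested. No other measurement bears on this result.

The compounds shown leave open whether a larger group on this oxygen, such as an ethyl or a longer chain, would give a similar number. They also leave open what an amine or a carboxylic acid would give in place of the hydroxy or methoxy group on this aromatic ring.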